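Halogen swap on two related cores, cytotoxicity notes

The source may report more compounds than this note shows. Statements on the series, on what has been measured and on what is new or still open speak of the compounds shown alone.

Measured compounds:
compound 1 `O=c1oc2ccc(F)cc2c(=O)n1-c1ccc(Br)cc1F` gives 7200 nM
compound 2 `O=c1oc2ccc(Br)cc2c(=O)n1-c1ccc(Br)cc1F` gives 7200 nM
compound 3 `O=C(Nc1ccc(Br)cc1F)c1cc(F)ccc1O` gives 7900 nM

All three were read in an ADME assay on RAW264.7 cells (Mus musculus) for cytotoxicity, read by MTT assay, with a stated time of 24 h; on this read-out lower numbers stand for higher toxicity in this test and higher numbers for lower toxicity in this test. Compound 2 differs from compound 1 by bromo in place of fluoro on an aromatic carbon, and that step is no change at the digits printed from compound 1 to compound 2 (within the scatter). The difference between the core of compound 1 and the core of compound 3 is not broken down here. Compound 4 `O=C(Nc1ccc(Br)cc1F)c1cc(Br)ccc1O` is not yet measured; it differs from compound 3 by bromo in place of fluoro on an aromatic carbon. This is the same kind of change as from compound 1 to compound 2, but the place differs: in compound 1 the aromatic carbon is part of a fused or bridged system of two rings, meta and para to a fused ring, whereas in compound 3 it is on a six-membered aromatic ring of carbon only, meta to a large group and para to a hydroxy group. Because the change from compound 1 to compound 2 gave no change at the digits printed from compound 1 to compound 2 (within the scatter), the expected step of no change at the digits printed from compound 3 to compound 4 (within the scatter) is likewise small. Compound 4 is therefore estimated at 7900 nM in this assay, with a range from 4000 nM to 16000 nM.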

Compound 4, half-maximal cytotoxic concentration: 7800 nM
Compound 4: middle estimate off by 1.0-fold (0.01 log units), on the high side; the range from low to high includes it.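

In this assay, bromo in place of fluoro gives a 1.0-fold lower number from compound 3 to compound 4 (0.01 log units; within the scatter), and the change carries from one core to the other without a measurable difference: the same change on two cores in this assay, no change at the digits printed (within the scatter) from compound 1 to compound 2 and a 1.0-fold lower number (0.01 log units; within the scatter) from compound 3 to compound 4, 1.0-fold (0.01 log units) apart, within the scatter of two such steps

On both cores, then, this halogen swap leaves the half-maximal cytotoxic concentration flat at the places tested. Among these compounds, two flat steps do not show that a step of real size would carry over between these cores, and they cover only this one change in this one assay.

Still open, on these data alone, is whether an amine or a carboxylic acid in place of the halogen would move the read-out on either core. Also open, as far as these compounds go, is what replacing the hydroxy group of compound 3 with an amine would do.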